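Hydroxy to methoxy on compound 1: expected read-out

The source may report more compounds than this note shows. Statements on the series, on what has been measured and on what is new or still open speak of the compounds shown alone.

Measured compounds:
compound 1 `O=C(Nc1cccc(-n2cc(-c3ccncc3)c(-c3cc(O)cc(Cl)c3)n2)c1)Nc1ccc(Cl)c(C(F)(F)F)c1` gives 88%
compound 2 `O=C(Nc1cccc(-n2cc(-c3ccncc3)c(-c3cc(O)cc(Cl)c3)n2)c1)Nc1ccc(Cl)c(Cl)c1` gives 95%

Going by the values given here, in a functional assay on HCT-15 cells (Homo sapiens) for inhibition, read by sulforhodamine B assay, with a stated time of 48 h, tested at 0.1 uM (on this read-out lower numbers stand for a stronger effect and higher numbers for a weaker effect at the one concentration tested), compound 1 gives 88%, the lowest of the two numbers so far. The nearest number is that of compound 2, which gives 95%; the step of a number 7 percentage points higher from compound 1 to compound 2 (within the scatter) is within the scatter, so the two compounds cannot be told apart on this read-out. Both numbers sit high, which on this read-out stands for a weak effect at the single concentration tested.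

Compound 3 `COc1cc(Cl)cc(-c2nn(-c3cccc(NC(=O)Nc4ccc(Cl)c(C(F)(F)F)c4)c3)cc2-c2ccncc2)c1` has not yet been measured. It differs from compound 1 in one place:
methyl in place of hydrogen on an oxygen on an aromatic ring

Among the compounds with values here, the only measured step, from compound 1 to compound 2, concerns the substituent on the urea-bearing aryl and not the oxygen, so no step speaks to this change directly. Within the data shown here, with only that step, within the scatter, as a guide, the expected step of a number 2 percentage points higher from compound 1 to compound 3 (within the scatter) is none beyond the scatter. Compound 3 is therefore estimated at 90%, with a range from 75% to 102%.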

Compound 3, a percentage reported as activity, at one concentration (the size of the read-out at that concentration, not a potency): 54%
The estimate for compound 3 lay 36 percentage points above the measured number, and the stated range ends above it.
By their numbers in this assay, from the lowest: compound 3; then compounds 1 and 2 (each within the scatter of the next).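

In this assay, going by these compounds alone, hydroxy to methoxy on the 3-chloro-5-hydroxyphenyl gives a number 34 percentage points lower from compound 1 to compound 3 (beyond the scatter), the first step beyond the scatter and one towards a stronger effect at the one concentration tested. The earlier pair showed no such response: the exchange on the other aromatic ring, chloro in place of trifluoromethyl, gives a number 7 percentage points higher from compound 1 to compound 2 (within the scatter), so the oxygen on the aromatic ring is the one place shown so far where a change moves this read-out, and the change there amounts to a single methyl of 1 heavy atom. Nothing shown here offers an explanation for the size of this step.

The compounds shown leave open whether ethoxy, a longer alkoxy chain or an amine at this place would follow methoxy, and so whether the step is specific to methyl on this oxygen or holds for other groups there. They also leave open whether hydroxy to methoxy gives a step of similar size on compound 2, and whether the stronger effect at the one concentration tested would also be seen at other concentrations.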